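The source may report more compounds than this note shows. Statements on the series, on what has been measured and on what is new or still open speak of the compounds shown alone.

Working notes on the series.

Compound 1 `c1ccc(CNCC2CCN(CCCc3c[nH]c4ccc(-n5cnnc5)cc34)CC2)cc1` is the reference point. In an assay on CHO cells for displacement of a labelled ligand from 5-hydroxytryptamine receptor 1D (Homo sapiens) (a lower number here means a stronger inhibitor, a higher number a weaker inhibitor), compound 1 gives 1.6 nM, the second highest of the three numbers recorded. Compound 3 `CC(=O)Nc1ccc([C@@H](C)NCC2CCN(CCCc3c[nH]c4ccc(-n5cnnc5)cc34)CC2)cc1` gives 1.5 nM, and the step of a 1.1-fold lower number from compound 1 to compound 3 (0.03 log units; within the scatter) is within the scatter. Compound 2 `c1ccc2c(c1)CCC2NC1CCN(CCCc2c[nH]c3ccc(-n4cnnc4)cc23)CC1` gives 8.9 nM, and the step of a 5.6-fold higher number from compound 1 to compound 2 (0.75 log units; beyond the scatter) is beyond the scatter, a modest weakening.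

Compound 4 `c1ccc(NCC2CCN(CCCc3c[nH]c4ccc(-n5cnnc5)cc34)CC2)nc1` differs from compound 1 in one place: pyridin-2-yl in place of benzyl on an amine nitrogen. Among the measured compounds shown here, of the two measured steps, the one from compound 1 to compound 3 bears most directly, since it also alters the group on the amine nitrogen and left the number where it was. The step from compound 1 to compound 2 is a larger rearrangement and weakened binding modestly. The change to compound 4 removes the benzyl group and places the six-membered aromatic ring with one hetero atom directly on the nitrogen, which neither measured step covers exactly, so only a small step is expected. For compound 4 the estimate is 4 nM, between 1.2 nM and 15 nM. The expected step is a 2.5-fold higher number from compound 1 to compound 4 (0.40 log units; beyond the scatter).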

Compound 4, half-maximal inhibitory concentration: 1.7 nM
The estimate for compound 4 lay 2.4-fold (0.37 log units) above the measured number, and the stated range covers the measured number.
By their numbers in this assay, from the lowest: compounds 3, 1 and 4 (each within the scatter of the next); then compound 2.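

In this assay the step of a 1.1-fold higher number from compound 1 to compound 4 (0.03 log units; within the scatter) is within the scatter, so on this amine nitrogen pyridin-2-yl, with its ring hetero atom and hydrogen-bond acceptor, can replace benzyl without a readable change. The step of a 1.1-fold higher number from compound 3 to compound 4 (0.05 log units; within the scatter) is also within the scatter, so the three groups on this nitrogen in compounds 1, 3 and 4 cannot be told apart, while the step of a 5.2-fold lower number from compound 2 to compound 4 (0.72 log units; beyond the scatter) is beyond the scatter and modest. No measurement shown explains why this position accepts these changes.

The compounds shown leave open whether this nitrogen would accept a saturated ring such as cyclohexyl, or a group carrying a carboxylic acid, as well as it accepts these aromatic groups. On these data alone, whether the ring nitrogen of pyridin-2-yl matters at all also remains open.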